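A few compounds are considered here, and "the series" means these few. Any claim that something is new, unique, unknown or untested is made for them only; others in the source may bear on it.

In an ADME assay on a cell-free system (plasma, Homo sapiens) for metabolic stability, read by LC-MS (a lower number here means that the compound disappears faster, a higher number that the compound lasts longer), compound 1 `NCc1ccc(C(=O)Nc2ccncc2F)cc1-c1cccc(NC(=O)c2cccc(C(=O)O)c2)c1` gives > 2 h, a limit of the assay. Compound 2 `NCc1ccc(C(=O)Nc2ccncc2F)cc1-c1cccc(NC(=O)c2cc(C(=O)O)ccc2F)c1` gives > 2 h, also a limit, so a step that the two limits leave unreadable from compound 1 to compound 2 tells nothing. Compound 3 `COCCOC(=O)c1ccc(F)c(C(=O)Nc2cccc(-c3cc(C(=O)Nc4ccncc4F)ccc3CN)c2)c1` stands at < 0.0834 h, again a limit. Going by the values given here, the one readable step is an at least 23-fold lower number from compound 2 to compound 3 (1.37 log units; beyond the scatter), with 2-methoxyethyl in place of hydrogen on an oxygen next to a carbonyl group. Compound 4 `COC(=O)c1ccc(F)c(C(=O)Nc2cccc(-c3cc(C(=O)Nc4ccncc4F)ccc3CN)c2)c1` differs from compound 3 by hydrogen in place of methoxymethyl on a saturated chain carbon bound to an oxygen next to a carbonyl group, or 2-methoxyethyl to methyl. That oxygen keeps a chain rather than regaining hydrogen, so the change does not undo an at least 23-fold lower number from compound 2 to compound 3 (1.37 log units; beyond the scatter), and little movement is expected. The expected step is an at least 1.1-fold higher number from compound 3 to compound 4 (0.07 log units; that floor lies within the scatter). For compound 4 the estimated half-life is 0.1 h, with an expected range of 0.04 h to 0.5 h.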

Compound 4, half-life: 0.883 h
Estimate against measurement, compound 4: 8.8-fold (0.95 log units) below; measured number above the stated range.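

In this assay, going by these compounds alone, the earlier compounds showed only that adding 2-methoxyethyl to the acid took the number to a limit; the change from 2-methoxyethyl to methyl now shows that the chain itself matters, with an at least 10-fold higher number from compound 3 to compound 4 (1.02 log units; beyond the scatter). Methyl does not fully match hydrogen on that oxygen, with an at least 2.2-fold lower number from compound 2 to compound 4 (0.35 log units; beyond the scatter), and the comparison with the unfluorinated acid gives an at least 2.2-fold lower number from compound 1 to compound 4 (0.35 log units; beyond the scatter). All three steps are bounds, as each partner of compound 4 sits at a limit.

As far as these compounds go, whether an ethyl or a longer chain in that place falls nearer compound 4 or compound 3 remains open. So does the effect of an amine at the end of such a chain, and the compounds shown give no cause for the step.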